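A few compounds are considered here, and "the series" means these few. Any claim that something is new, unique, unknown or untested is made for them only; others in the source may bear on it.

Among the compounds with values here, compound 2 `CC(C)N(Cc1cccc(OCCCCCC(=O)O)c1)C(=O)c1ccc(-c2ccc(Cl)c(Cl)c2)cc1` is one of two compounds measured in an ADME assay on BJ cells (Homo sapiens) for cytotoxicity, read by CellTiter-Glo and resazurin assay, with a stated time of 72 h; a higher number here means that more compound is needed for the effect, a lower number that less compound is needed. In this assay compound 2 reaches only the limit of the test, > 26000 nM, so no number is known for it. Compound 1 `CCOc1cccc(-c2ccc(C(=O)N(Cc3cccc(OCCCCCC(=O)O)c3)C(C)C)cc2)c1` likewise gives in this assay the limit > 20800 nM. The step that the two limits leave unreadable from compound 1 to compound 2 cannot be read: the limit of > 20800 nM in this assay, at which 1 of the 2 values shown sits, and the limit of > 26000 nM in this assay, at which 1 of the 2 values shown sits, show both values sitting at the limits of the test.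

The unmeasured compound 3 `CC(C)N(Cc1cccc(OCCCCCC(=O)O)c1)C(=O)c1ccc(-c2cccc(S(C)(=O)=O)c2)cc1` differs from compound 2 in one place: 3-(methylsulfonyl)phenyl in place of 3,4-dichlorophenyl on an aromatic carbon. Within the data shown here, the only measured step, from compound 1 to compound 2, also swaps the group in this same place, and it left both compounds at their limits. No readable step bears on the change to compound 3, so the expectation is that compound 3 will again show no cytotoxicity within the tested range, and the expected step of an at least 1.0-fold lower number from compound 2 to compound 3 (0.01 log units; that floor lies within the scatter) is taken as none beyond the scatter. Compound 3 is estimated at 25000 nM, within 8000 nM to 60000 nM, most likely reported as a limit.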

Compound 3, half-maximal effective concentration: > 26000 nM
Compound 3: only a limit was reported; the forecaster's own chance of this, stated with the estimate: 85%; middle value at least 1.0-fold (0.01 log units) from the limit.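

Within the data shown here, compound 1, compound 2 and compound 3 all stand at limits of the test in this assay, so no step between them can be read. The compounds shown leave open what concentration of each would produce the effect, and whether changing this one group alters it.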